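Swapping the chain on the core: isobutyl out, methoxy in

The compounds below may be only part of what the source reports. "The series", "measured", "known", "first", "only" and "open" are said of these compounds alone.

Compound 2 `COc1cc(Cc2nc3c(N)ncnc3n2CCCC(C)C)cc(OC)c1OC` is the weaker-looking of the two measured compounds on paper, although only by a margin that means little. Among the measured compounds shown here, in a functional assay on MCF7 cells (Homo sapiens) for antiproliferative activity (on this read-out higher numbers stand for weaker inhibition and lower numbers for stronger inhibition), compound 2 gives 69200 nM, the highest of the two numbers so far. Its nearest neighbour is compound 1 `CC/C=C/Cn1c(Cc2cc(OC)c(OC)c(OC)c2)nc2c(N)ncnc21`, which in this assay gives 46800 nM; the step of a 1.5-fold higher number from compound 1 to compound 2 (0.17 log units; within the scatter) is within the scatter, so the two cannot be ordered.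

Compound 3 `COCCn1c(Cc2cc(OC)c(OC)c(OC)c2)nc2c(N)ncnc21` keeps everything of compound 2 except one change: methoxy in place of isobutyl on a saturated chain carbon, two bonds along the chain from an aromatic nitrogen. For the measured compounds named here, the only measured step, from compound 1 to compound 2, altered the same chain at a different point and moved the number by a 1.5-fold higher number from compound 1 to compound 2 (0.17 log units; within the scatter), which is no movement at all within the scatter. It bears on the new step only loosely, as it says that this chain tolerated one exchange without any shift beyond the scatter.

On that basis no step beyond the scatter is expected for compound 3, meaning a 1.2-fold lower number from compound 2 to compound 3 (0.06 log units; within the scatter) in this assay. Compound 3 is therefore estimated at 60000 nM, with a range from 20000 nM to 200000 nM.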

Compound 3, half-maximal inhibitory concentration: 64600 nM
Compound 3: middle estimate off by 1.1-fold (0.03 log units), on the low side; measured number inside the range.
By their numbers in this assay, from the lowest: compounds 1, 3 and 2 (each within the scatter of the next).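

In this assay the exchange of isobutyl for methoxy, on a saturated chain carbon two bonds along the chain from an aromatic nitrogen, gives a 1.1-fold lower number from compound 2 to compound 3 (0.03 log units; within the scatter) and stays within the scatter. Read against the other chain, the exchange of but-1-en-1-yl for methoxymethyl gives a 1.4-fold higher number from compound 1 to compound 3 (0.14 log units; within the scatter) and also stays within the scatter, so compound 1, compound 2 and compound 3 cannot be ordered. The earlier step had only replaced one all-carbon chain with another, whereas these steps show that a chain ending in methoxy, with a hydrogen-bond acceptor that isobutyl lacks and fewer heavy atoms in the entering group, also produces no step beyond the scatter; no evidence is available to explain why the number holds across these chains.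

All three chains shown are open-chain groups without a charge, so it remains open whether a terminal amine, a carboxylic acid or a phenyl ring at this position would move the number beyond the scatter. A much shorter chain, such as methyl or ethyl, is equally untested by these compounds.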